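Aryloxypropyl piperidines: naphthalenyl ether as next analogue

The compounds below may be only part of what the source reports. "The series", "measured", "known", "first", "only" and "open" are said of these compounds alone.

Measured so far in a functional assay (aorta) with Oryctolagus cuniculus as the target; on this read-out higher numbers stand for weaker binding and lower numbers for tighter binding:
compound 1 `COc1cc(C(C)=O)ccc1OCCCN1CCC(C(c2ccc(F)cc2)c2ccc(F)cc2)CC1`, 1.59 nM
compound 2 `COc1cc(C(C)=O)ccc1OCCCCN1CCC(C(c2ccc(F)cc2)c2ccc(F)cc2)CC1`, 2.51 nM
compound 3 `N#Cc1ccc(OCCCN2CCC(C(c3ccc(F)cc3)c3ccc(F)cc3)CC2)cc1`, 5.01 nM

Compound 3 shows the highest number of the three; compound 2 sits within the scatter of it, and compound 1 gives a number beyond the scatter below it, as a 3.2-fold higher number from compound 1 to compound 3 (0.50 log units; beyond the scatter) shows.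

Compound 4 `Fc1ccc(C(c2ccc(F)cc2)C2CCN(CCCOc3ccc4ccccc4c3)CC2)cc1` is the next analogue. naphthalen-2-yl in place of 4-cyanophenyl on an oxygen on a saturated carbon

Within the data shown here, the only measured step that bears on this change is the swap of the aryl group on the oxygen, a 3.2-fold higher number from compound 1 to compound 3 (0.50 log units; beyond the scatter), a modest step. Among the measured compounds shown here, no measured pair swaps to naphthalen-2-yl, so the direction is open; a step of similar or smaller size in this assay is expected either way, centred near no change.

Compound 4 is expected to give 5 nM, range 1.5 nM to 16 nM, i.e. a step of a 1.0-fold lower number from compound 3 to compound 4 (0.00 log units; within the scatter).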

Compound 4, dissociation constant: 7.94 nM
Estimate against measurement, compound 4: 1.6-fold (0.20 log units) below, within the range that was stated.
By their numbers in this assay, from the lowest: compounds 1, 2, 3 and 4 (each within the scatter of the next, the first and the last beyond it).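

In this assay, naphthalen-2-yl on the oxygen replaces 4-cyanophenyl with no step beyond the scatter (a 1.6-fold higher number from compound 3 to compound 4 (0.20 log units; within the scatter)), so a second aromatic ring of carbon only, with the nitrile gone, leaves the read-out within the scatter at this place. Set against the 4-acetyl-2-methoxyphenyl group, the same naphthalen-2-yl ether gives a modest step (a 5.0-fold higher number from compound 1 to compound 4 (0.70 log units; beyond the scatter)), and compound 1 keeps the lowest number of compounds 1, 3 and 4. Nothing available explains either step.

From the compounds shown here alone, whether 4-acetylphenyl or 2-methoxyphenyl alone would match compound 1 remains open. Also open, going by these compounds, is how naphthalen-2-yl behaves on the longer chain of compound 2.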